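This account rests on a few compounds, and the source may have more. Where it says the series, first, only, none or still open, it means among the compounds named here.

Three compounds share one core and differ at a single aromatic carbon. Compound 1 `Cc1cc(N2CC[C@@H](C)[C@@H](N(C)c3ncnc4[nH]ccc34)C2)n2ncnc2n1` carries hydrogen there, compound 2 `CCCSc1nc2nc(C)cc(N3CC[C@@H](C)[C@@H](N(C)c4ncnc5[nH]ccc45)C3)n2n1` carries propylsulfanyl, and compound 3 `Cc1cc(N2CC[C@@H](C)[C@@H](N(C)c3ncnc4[nH]ccc34)C2)n2nc(SCc3cc(Cl)ccc3Cl)nc2n1` carries (2,5-dichlorobenzyl)sulfanyl. In a functional assay on MGC-803 cells (Homo sapiens) for inhibition, read by MTT assay, with a stated time of 72 h (on this read-out lower numbers stand for stronger inhibition and higher numbers for weaker inhibition), compound 1 gives 4350 nM, compound 2 gives 15500 nM and compound 3 gives 9850 nM. Compound 3 thus holds the second highest of the three numbers: its step from compound 2, a 1.6-fold lower number from compound 2 to compound 3 (0.20 log units; within the scatter), stays within the scatter, whereas a 2.3-fold higher number from compound 1 to compound 3 (0.35 log units; beyond the scatter) and a 3.6-fold higher number from compound 1 to compound 2 (0.55 log units; beyond the scatter) both lie beyond it.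

Compound 4 `Cc1cc(N2CC[C@@H](C)[C@@H](N(C)c3ncnc4[nH]ccc34)C2)n2nc(SCc3ccc(Cl)cc3)nc2n1` differs from compound 3 in one place: 4-chlorophenyl in place of 2,5-dichlorophenyl on a saturated chain carbon bound to a sulfur. Within the data shown here, no measured step matches this change exactly. Among the measured compounds shown here, the only step that alters the group on a saturated chain carbon bound to a sulfur, a 1.6-fold lower number from compound 2 to compound 3 (0.20 log units; within the scatter), stays within the scatter even though it exchanges ethyl for 2,5-dichlorophenyl. The two steps beyond the scatter, a 3.6-fold higher number from compound 1 to compound 2 (0.55 log units; beyond the scatter) and a 2.3-fold higher number from compound 1 to compound 3 (0.35 log units; beyond the scatter), concern putting a sulfanyl group in place of hydrogen, and compound 4 keeps such a group. For this assay the account therefore expects no step beyond the scatter, a 1.1-fold lower number from compound 3 to compound 4 (0.04 log units; within the scatter). Compound 4 is estimated at 9000 nM, with a range from 4500 nM to 18000 nM.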

Compound 4, half-maximal inhibitory concentration: 16000 nM
Beside the measured number, compound 4's estimate is 1.8-fold (0.25 log units) below it, within the range that was stated.
By their numbers in this assay, from the lowest: compound 1; then compounds 3, 2 and 4 (each within the scatter of the next).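

In this assay, the group on a saturated chain carbon bound to a sulfur has now been changed in two further ways: 4-chlorophenyl in place of 2,5-dichlorophenyl gives a 1.6-fold higher number from compound 3 to compound 4 (0.21 log units; within the scatter), and 4-chlorophenyl in place of ethyl gives a 1.0-fold higher number from compound 2 to compound 4 (0.01 log units; within the scatter). With the earlier step from ethyl to 2,5-dichlorophenyl, this means that compound 2, compound 3 and compound 4 cannot be told apart in this read-out, although they carry three different groups at this place and the change of chlorine count between compound 3 and compound 4 moves the number only within the scatter. Against hydrogen on the aromatic carbon, (4-chlorobenzyl)sulfanyl gives a 3.7-fold higher number from compound 1 to compound 4 (0.57 log units; beyond the scatter), so all three sulfanyl compounds shown stand beyond the scatter from compound 1, and none of them goes against this.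

Nothing available explains these numbers.

As far as these compounds go, whether an amine or a carboxylic acid on that saturated chain carbon would break this flat picture stays open, as does whether an amine in place of the sulfanyl group would give a number that stays within the scatter of compound 1.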